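A few compounds are considered here, and "the series" means these few. Any claim that something is new, unique, unknown or untested is made for them only; others in the source may bear on it.

Compound 1, `O=C(Nc1nc2ccc(F)cc2s1)C1CC1`: in an ADME assay on H9c2 cells (Rattus norvegicus) for cytotoxicity (on this read-out lower numbers stand for stronger inhibition and higher numbers for weaker inhibition), compound 1 gives > 50000 nM, which is a limit of the assay.
Compound 2, `Cc1ccc2nc(NC(=O)C3CC3)sc2c1`: compound 2 gives > 50000 nM, again a limit.
Compound 3, `O=C(Nc1nc2cc(F)c(C(F)(F)F)cc2s1)C1CC1`: compound 3 gives > 50000 nM, also a limit.

Compound 2 differs from compound 1 by methyl in place of fluoro on an aromatic carbon; the step that the two limits leave unreadable from compound 1 to compound 2 cannot be read, because of the limit of > 50000 nM in this assay, at which 3 of the 3 values shown sit. Compound 4, `Cc1cc2nc(NC(=O)C3CC3)sc2cc1C(F)(F)F`, is not yet measured. It differs from compound 3 by methyl in place of fluoro on an aromatic carbon, the same kind of change as from compound 1 to compound 2, but here the place is ortho to a trifluoromethyl group (4 heavy atoms). The difference between the two cores is not broken down here. Compound 4 is expected to sit near the limit as well, a step that the limit leaves unreadable from compound 3 to compound 4, because of the limit of > 50000 nM in this assay, at which 3 of the 3 values shown sit. The estimate for compound 4 is 80000 nM, between 25000 nM and 300000 nM.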

Compound 4, half-maximal inhibitory concentration: 36000 nM
Estimate against measurement, compound 4: 2.2-fold (0.35 log units) above; the measured number falls inside the stated range.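

In this assay, methyl in place of fluoro gives an at least 1.3-fold lower number from compound 3 to compound 4 (0.14 log units; that floor lies within the scatter), so this step alone does not establish a real change. Compound 4, at 36000 nM, is the only compound shown with a number rather than a limit, so the change cannot be compared in size across the two cores, and carrying it from one core to the other is neither confirmed nor ruled out. The step from compound 1 to compound 2 cannot be read, since both of its values are limits: the limit of > 50000 nM in this assay, at which 3 of the 4 values shown sit.

The compounds shown leave open what an amine or a carboxylic acid would give at this place. As far as these compounds go, whether a nitrile there, or a longer chain on the carbonyl, would give a number rather than a limit also stays open.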